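A few compounds are considered here, and "the series" means these few. Any claim that something is new, unique, unknown or untested is made for them only; others in the source may bear on it.

- compound 1 `C=CCCCCOc1ccccc1-c1cnc(OCCC=C)n1C`: 17000 nM
- compound 2 `C#CCCCCOc1ncc(-c2ccccc2OC)n1C`: 38000 nM

Both values come from a functional assay on SK-MEL-28 cells (Homo sapiens) for inhibition, read by colorimetric assay and MTT assay, with a stated time of 72 h; a higher number here means a weaker inhibitor, a lower number a stronger inhibitor. Compound 2 has the higher number of the two, and the gap to compound 1 lies beyond the scatter.

Next in the series is compound 3 `C=CCCOc1ncc(-c2ccccc2OC)n1C`. The change is vinyl in place of but-3-yn-1-yl on a saturated chain carbon, two bonds along the chain from an oxygen on an aromatic ring, with vinyl in place of but-3-yn-1-yl on a saturated chain carbon, two bonds along the chain from an oxygen on an aromatic ring.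

Within the data shown here, no measured pair isolates this change, so the expectation is tentative. Compound 1, at 17000 nM, also carries a (but-3-en-1-yl)oxy group, but it differs from compound 3 elsewhere as well and offers only a weak hint towards a lower number. In this assay, no step beyond the scatter is expected, and the estimated change is a 1.1-fold lower number from compound 2 to compound 3 (0.04 log units; within the scatter). For compound 3 the expected value is 35000 nM, with an estimated range of 14000 nM to 90000 nM.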

Compound 3, half-maximal inhibitory concentration: 21000 nM
Beside the measured number, compound 3's estimate is 1.7-fold (0.22 log units) above it, within the range that was stated.
By their numbers in this assay, from the lowest: compounds 1, 3 and 2 (each within the scatter of the next, the first and the last beyond it).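

In this assay, among these compounds, vinyl in place of but-3-yn-1-yl on this saturated chain carbon gives a 1.8-fold lower number from compound 2 to compound 3 (0.26 log units; within the scatter), so this exchange of a longer alkyne chain for a shorter alkene chain produces no step that can be told from the scatter. On the other aryl oxygen substituent, hydrogen in place of pent-4-en-1-yl gives a 1.2-fold higher number from compound 1 to compound 3 (0.09 log units; within the scatter), so the step at this second position also stays inside the scatter in this assay. No measurement shown here speaks to the reason for either result.

Chain length and the triple-to-double-bond exchange change together from compound 2 to compound 3, so the contribution of each remains unresolved. Going by these compounds, how an amine or a carboxylic acid in place of vinyl on this saturated chain carbon would read in this assay also remains open.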